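Ortho substituent on the benzyl thioether: bromo to methyl

A few compounds are considered here, and "the series" means these few. Any claim that something is new, unique, unknown or untested is made for them only; others in the source may bear on it.

Compound 3 `COc1cc(-c2nnc(SCc3ccccc3Br)o2)ccc1O` has the highest number of the three measured, in a functional assay on cells (T-cell, Mus musculus, strain BALB/c) for inhibition, read by MTT assay, with stated times of 24 h and 72 h (a higher number here means a weaker inhibitor, a lower number a stronger inhibitor), giving 17800 nM. Compound 1 `COc1cc(-c2nnc(SCc3ccccc3F)o2)ccc1O` gives 5790 nM, and compound 2 `COc1cc(-c2nnc(SCc3ccc(F)cc3F)o2)ccc1O` gives 9690 nM; the step of a 3.1-fold higher number from compound 1 to compound 3 (0.49 log units; beyond the scatter) is beyond the scatter, while a 1.8-fold higher number from compound 2 to compound 3 (0.26 log units; within the scatter) and a 1.7-fold higher number from compound 1 to compound 2 (0.22 log units; within the scatter) are not.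

Compound 4 `COc1cc(-c2nnc(SCc3ccccc3C)o2)ccc1O` differs from compound 3 by methyl in place of bromo on an aromatic carbon. Going by the values given here, no measured step swaps bromo for methyl; the only step at this aromatic carbon is a 3.1-fold higher number from compound 1 to compound 3 (0.49 log units; beyond the scatter), which went up, and the remaining steps in this assay stayed within the scatter. With one informative step and nothing directly on methyl, the expectation for compound 4 is a number near that of compound 3, leaning slightly lower toward compound 1, and the expected step of a 1.5-fold lower number from compound 3 to compound 4 (0.17 log units; within the scatter) is taken to lie within the scatter. Compound 4 is therefore estimated at 12000 nM, with a range of 5000 nM to 30000 nM.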

Compound 4, half-maximal inhibitory concentration: 8420 nM
For compound 4 the middle estimate is 1.4-fold (0.15 log units) above the measured one, within the range that was stated.
By their numbers in this assay, from the lowest: compounds 1, 4, 2 and 3 (each within the scatter of the next, the first and the last beyond it).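

In this assay the aromatic carbon ortho to a large group now carries three groups across the series, and bromo separates from methyl (with a 2.1-fold lower number from compound 3 to compound 4 (0.33 log units; beyond the scatter)) as it did from fluoro. Methyl and fluoro at this carbon do not separate (with a 1.5-fold higher number from compound 1 to compound 4 (0.16 log units; within the scatter)), and 2-methylphenyl does not separate from 2,4-difluorophenyl (with a 1.2-fold lower number from compound 2 to compound 4 (0.06 log units; within the scatter)), so bromo is the group that departs here, though compound 2 stays within the scatter of compound 3 and goes against any clean split. Nothing on hand accounts for the difference between bromo and methyl.

Open, on these data alone, is how the number at this carbon responds to an amine, a carboxylic acid or a methoxy group. Also open, as far as these compounds go, is whether a longer chain such as ethyl or propyl stays with methyl and fluoro or moves toward bromo.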